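The source may hold more compounds than are shown below. What is called first, only, known or untested is meant among the compounds shown, and "the series" means these compounds.

Measured so far in a functional assay on KM12 cells (Homo sapiens) for inhibition, read by sulforhodamine B assay, with a stated time of 48 h; a lower number here means that less compound is tolerated, a higher number that more compound is tolerated:
compound 1 `Nc1cc(N)c2nc(-c3ccccc3)c(Sc3ccc(F)cc3)nc2c1`: < 100000 nM
compound 2 `COc1cc(CNc2nc3cc(N)cc(N)c3nc2-c2ccccc2)cc(OC)c1OC`: < 50200 nM
compound 3 `CCOC(=O)[C@H](CCC(=O)O)NC(=O)c1ccc(Oc2nc3cc(N)cc(N)c3nc2-c2ccccc2)cc1`: < 100000 nM

In this assay compound 1 gives < 100000 nM, which is a limit of the assay and not a number. Compound 2 likewise gives only a limit, < 50200 nM. Compound 3 also gives only a limit, < 100000 nM. On the numbers shown, the limit of < 100000 nM in this assay, at which 2 of the 3 values shown sit, and (the limit of < 50200 nM in this assay, at which 1 of the 3 values shown sits); compound 1 sits at the first of these, so nothing places it above or below the other two. Compound 4 `COc1ccc(Sc2nc3cc(N)cc(N)c3nc2-c2ccccc2)cc1` differs from compound 1 in one place: methoxy in place of fluoro on an aromatic carbon. Going by the values given here, no step between measured compounds is known, so the data give no size for such a change. Every value shown is a limit. The step from compound 1 is expected to be a number no lower from compound 1 to compound 4 (the limit leaves the size open), none beyond the scatter. Compound 4 is estimated at 100000 nM, between 30000 nM and 300000 nM.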

Compound 4, concentration lethal to 50% of the cells: < 100000 nM
Compound 4: no number, only a limit; the forecaster's own chance of this, stated with the estimate: 80%; the middle value lies on the limit itself.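

In this assay compound 4 gives < 100000 nM, which is a limit of the assay and not a number. Going by these compounds alone, no step between compound 1 and compound 4 can be read, since both values are limits: the limit of < 100000 nM in this assay, at which 3 of the 4 values shown sit. The compounds shown leave open whether methoxy in place of fluoro changes the value at all.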